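A few compounds are considered here, and "the series" means these few. Any claim that something is new, unique, unknown or untested is made for them only; others in the source may bear on it.

Measured so far in a functional assay on U-87MG ATCC cells for antiproliferative activity against U-87 MG (Homo sapiens), read by MTT assay, with a stated time of 48 h, tested at 50 uM; a higher number here means a weaker effect of the compound at the concentration tested, a lower number a stronger effect:
compound 1 `Cc1nc(-c2ccc(Cl)cc2)sc1C(=O)CSc1nc(-c2ccccc2)c(C#N)c(=O)[nH]1`, giving 41.6%;
compound 2 `COc1ccc(-c2nc(C)c(C(=O)CSc3nc(-c4ccc(Cl)cc4)c(C#N)c(=O)[nH]3)s2)cc1`, giving 48%.

Compound 1 holds the lower of the two numbers, but compound 2 sits close to it, within the usual scatter, so the two cannot be ranked. Compound 3 `Cc1nc(-c2ccc(Cl)cc2)sc1C(=O)CSc1nc(-c2ccc(Cl)c(Cl)c2)c(C#N)c(=O)[nH]1` is not yet measured. It differs from compound 1 in one place: 3,4-dichlorophenyl in place of phenyl on an aromatic carbon. Among the measured compounds shown here, no step between measured compounds is known, so there is no basis for a step beyond the scatter in either direction. For compound 3 in this assay, a value near that of compound 1 is expected, 38% with a range of 20% to 58%, which means an expected a number 3.6 percentage points lower from compound 1 to compound 3 (within the scatter).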

Compound 3, a percentage reported as activity, at one concentration (the size of the read-out at that concentration, not a potency): 93.9%
Estimate against measurement, compound 3: 55.9 percentage points below, and the stated range ends below it.
By their numbers in this assay, from the lowest: compounds 1 and 2 (each within the scatter of the next); then compound 3.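

In this assay, putting 3,4-dichlorophenyl in place of phenyl on this aromatic carbon gives a number 52.3 percentage points higher from compound 1 to compound 3 (beyond the scatter), a much weaker effect at the concentration tested. Among the compounds shown here, this shows that the position does not tolerate every aromatic group equally, which compounds 1 and 2 could not show, as no single-place step linked them. Nothing available here accounts for the loss. Open remains whether an aminophenyl or a carboxyphenyl group on this carbon would read closer to compound 1 or to compound 3. As far as these compounds go, whether the step would hold with other groups elsewhere on the core is also open.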